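The source may hold more compounds than are shown below. What is called first, only, known or untested is meant among the compounds shown, and "the series" means these compounds.

For the measured compounds named here, compound 3 `C[C@H](NC1CCN(CCCc2c[nH]c3ccc(-n4cnnc4)cc23)CC1)c1ccccc1` gives 0.6 nM in an assay on CHO cells for binding affinity to 5-hydroxytryptamine receptor 1D (Homo sapiens) (a lower number here means a stronger inhibitor, a higher number a weaker inhibitor), the lowest of the three numbers measured so far. Compound 1 `COC[C@H](NC1CCN(CCCc2c[nH]c3ccc(-n4cnnc4)cc23)CC1)c1ccccc1` gives 3 nM and compound 2 `NC(=O)OC[C@H](NC1CCN(CCCc2c[nH]c3ccc(-n4cnnc4)cc23)CC1)c1ccccc1` gives 4.7 nM; the steps to compound 3 are a 5.0-fold lower number from compound 1 to compound 3 (0.70 log units; beyond the scatter) and a 7.8-fold lower number from compound 2 to compound 3 (0.89 log units; beyond the scatter), both beyond the scatter, so compound 3 is the most potent of the three. The remaining pair, a 1.6-fold higher number from compound 1 to compound 2 (0.19 log units; within the scatter), stays within the scatter.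

Compound 4 `CC(=O)Nc1ccc([C@@H](C)NC2CCN(CCCc3c[nH]c4ccc(-n5cnnc5)cc34)CC2)cc1` differs from compound 3 by 1-(4-acetamidophenyl)ethyl in place of 1-phenylethyl on an amine nitrogen. Going by the values given here, none of the measured steps bears on this change: all three concern the substituent on the saturated chain carbon, and the aromatic ring carried nothing in any measured compound. Among the compounds with values here, there is therefore no measured precedent for the direction or size of the step in this assay, and the working assumption is a step within the scatter or a modest one.

Compound 4 is expected near 1.2 nM, with a range from 0.3 nM to 5 nM. The estimated step is a 2.0-fold higher number from compound 3 to compound 4 (0.30 log units; within the scatter).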

Compound 4, half-maximal inhibitory concentration: 29 nM
The estimate for compound 4 lay 24-fold (1.38 log units) below the measured number, and the stated range ends below it.
By their numbers in this assay, from the lowest: compound 3; then compounds 1 and 2 (each within the scatter of the next); then compound 4.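

The aromatic ring of the 1-phenylethyl group on the amine nitrogen turns out to be a sensitive place in this assay: 1-(4-acetamidophenyl)ethyl in place of 1-phenylethyl gives a 48-fold higher number from compound 3 to compound 4 (1.68 log units; beyond the scatter) and so exceeds both steps seen at the saturated chain carbon. Compound 4 also stands apart from the two compounds substituted on that chain carbon, with a 6.2-fold higher number from compound 2 to compound 4 (0.79 log units; beyond the scatter) and a 9.7-fold higher number from compound 1 to compound 4 (0.99 log units; beyond the scatter) as the steps, so the change on the ring weighs more here than either methoxy or carbamoyloxy on the chain. No supporting measurement accounts for the size of this step.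

From the compounds shown here alone, it remains open whether a fluorine, a methyl or a free amine on the ring would stay close to compound 3 or follow compound 4. Whether the acetyl part or the ring nitrogen carries the step also stays unresolved.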